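This account rests on a few compounds, and the source may have more. Where it says the series, first, only, none or still open, it means among the compounds named here.

Measured compounds:
- compound 1 `CC(C)=CCC/C(C)=C/COc1cc(=O)n(CCCO)c2c1CC(CC=C(C)C)C(C)(C)C2`: 18.4%
- compound 2 `COc1ccc(OCCCOc2cc(=O)n(CCCO)c3c2CC(CC=C(C)C)C(C)(C)C3)cc1`: 4.1%

In a functional assay on PANC-1 cells (Homo sapiens) for inhibition, read by MTT assay, with a stated time of 24 h, tested at 10 uM (on this read-out lower numbers stand for less inhibition and higher numbers for more inhibition at the one concentration tested (going by the name of the read-out)), compound 1 gives 18.4% and stands highest of the two numbers, with compound 2 the nearest at 4.1%. Among the measured compounds shown here, the one step between them, a number 14.3 percentage points lower from compound 1 to compound 2 (beyond the scatter), went with 2-(4-methoxyphenoxy)ethyl in place of 2,6-dimethylhepta-1,5-dien-1-yl on a saturated chain carbon bound to an oxygen on an aromatic ring, and is beyond the scatter.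

Compound 3 `CC(C)=CCC1Cc2c(OC(=O)Nc3ccc(F)cc3)cc(=O)n(CCCO)c2CC1(C)C` is not yet measured. It differs from compound 1 by (4-fluorophenyl)carbamoyl in place of 3,7-dimethylocta-2,6-dien-1-yl on an oxygen on an aromatic ring: the 3,7-dimethylocta-2,6-dien-1-yl chain leaves and a (4-fluorophenyl)carbamoyl group enters, so that ((4-fluorophenyl)carbamoyl)oxy takes the place of (3,7-dimethylocta-2,6-dien-1-yl)oxy.

For the measured compounds named here, the only step that bears on this is the one from compound 1 to compound 2, where the dienyl chain was also exchanged for a group carrying a six-membered aromatic ring and the number fell modestly. Exchanging the chain again, now for a carbamate with an aromatic ring, is expected to move this assay in the same direction, by a step of about a number 8.4 percentage points lower from compound 1 to compound 3 (within the scatter), though a result within the scatter would not surprise. Compound 3 is therefore estimated at 10%, with a range from 0% to 22%.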

Compound 3, a percentage reported as inhibition, at one concentration (the size of the read-out at that concentration, not a potency): 0%
The estimate for compound 3 lay 10 percentage points above the measured number; low and high end bracket the measured number.
By their numbers in this assay, from the lowest: compounds 3 and 2 (each within the scatter of the next); then compound 1.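

At the oxygen on an aromatic ring in this assay, (4-fluorophenyl)carbamoyl in place of 3,7-dimethylocta-2,6-dien-1-yl gives a number 18.4 percentage points lower from compound 1 to compound 3 (beyond the scatter), so a second replacement of the open dienyl chain by a group carrying a six-membered aromatic ring also goes with a lower number, and neither of the two compounds with such a group goes against this. Compound 3 at 0% and compound 2 at 4.1% lie within the scatter of each other, so this read-out does not separate the carbamoyl link from the ether-linked 4-methoxyphenoxy chain. Nothing at hand gives a reason for the lower number at this position.

Still open, on these data alone, is whether the number follows the loss of the dienyl chain or the arrival of the aromatic ring, which a saturated octyl chain, a shorter 3-methylbut-2-en-1-yl group or an octylcarbamoyl group on the same oxygen would help to separate. As far as these compounds go, the part played by the fluorine in compound 3 is equally open, and a plain phenylcarbamoyl group would address it.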